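The source may report more compounds than this note shows. Statements on the series, on what has been measured and on what is new or still open speak of the compounds shown alone.

Measured so far:
compound 1 `CS(=O)(=O)c1cc(C(=O)N=C(N)N)c(Cl)cc1Cl` — 140 nM
compound 2 `Cc1cc(C2CCC2)c(S(C)(=O)=O)cc1C(=O)N=C(N)N` — 8.2 nM
compound 3 `Cc1cc(-c2cc(C(F)(F)F)cc(C(F)(F)F)c2)c(S(C)(=O)=O)cc1C(=O)N=C(N)N` — 2800 nM

In a functional assay for inhibition of sodium/hydrogen exchanger (Oryctolagus cuniculus) (a higher number here means a weaker inhibitor, a lower number a stronger inhibitor), compound 2 has the lowest number of the three; compound 1 stands nearest and compound 3 furthest, both beyond the scatter. Compound 4 `Cc1cc(Sc2ccccc2)c(S(C)(=O)=O)cc1C(=O)N=C(N)N` has not yet been measured. It differs from compound 2 in one place: phenylsulfanyl in place of cyclobutyl on an aromatic carbon. For the measured compounds named here, no step between measured compounds that differ in a single place is available as a guide, but compound 3, which also carries a six-membered aromatic ring of carbon only in the same place, gives 2800 nM in this assay. Given this, a weaker inhibitor is expected for compound 4, with a step of an 11-fold higher number from compound 2 to compound 4 (1.04 log units; beyond the scatter) estimated beyond the scatter. The estimate for compound 4 is 90 nM, within a range from 20 nM to 600 nM.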

Compound 4, half-maximal inhibitory concentration: 14 nM
For compound 4 the middle estimate is 6.4-fold (0.81 log units) above the measured one, and the stated range ends above it.
By their numbers in this assay, from the lowest: compounds 2 and 4 (each within the scatter of the next); then compound 1; then compound 3.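

In this assay, phenylsulfanyl in place of cyclobutyl on this aromatic carbon gives a 1.7-fold higher number from compound 2 to compound 4 (0.23 log units; within the scatter), so the two groups cannot be told apart here despite their different rings. Compound 3 gives 2800 nM and compound 4 gives 14 nM, which shows that a six-membered aromatic ring of carbon only in this place does not by itself set the number. No measurement shown accounts for this match or this gap. On these data alone, it remains open whether the sulfur link or the two trifluoromethyl groups separate compound 3 from compound 4. A plain phenyl, a phenoxy group or an amine in this place could help to settle that.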